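Chloro to bromo on a thiosemicarbazone isatin core

The source may report more compounds than this note shows. Statements on the series, on what has been measured and on what is new or still open speak of the compounds shown alone.

The study follows two compounds sharing a core measured in a functional assay on MCF7 cells (Homo sapiens) for cytotoxicity, read by sulforhodamine B assay, with a stated time of 48 h (a lower number here means a stronger inhibitor of growth, a higher number a weaker inhibitor of growth), and one that has not yet been measured there. Compound 1 `O=C1C(=O)N(CN2CCN(c3ccnc4cc(C(F)(F)F)ccc34)CC2)c2ccccc21` gives 34000 nM in this assay. Compound 2 `NC(=S)N/N=C1/C(=O)N(CN2CCN(c3ccnc4cc(Cl)ccc34)CC2)c2cc(Cl)ccc21` gives 22500 nM in this assay, and the gap between compound 2 and compound 1 lies within the scatter of repeated measurements, so the two numbers cannot be told apart.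

Compound 3 `NC(=S)N/N=C1/C(=O)N(CN2CCN(c3ccnc4cc(Cl)ccc34)CC2)c2cc(Br)ccc21` differs from compound 2 in one place: bromo in place of chloro on an aromatic carbon. Among the measured compounds shown here, no step between measured compounds bears on this exchange, so the expectation rests on the exchange alone, a bromo in place of a chloro on an aromatic carbon. Such a swap is expected to give no step beyond the scatter, in no clear direction, so the step from compound 2 to compound 3 is estimated as a 1.1-fold lower number from compound 2 to compound 3 (0.05 log units; within the scatter). On this basis compound 3 is expected to give about 20000 nM in this assay, with a range from 10000 nM to 45000 nM.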

Compound 3, concentration for 50% growth inhibition: 11400 nM
The estimate for compound 3 lay 1.8-fold (0.24 log units) above the measured number; the range from low to high includes it.
By their numbers in this assay, from the lowest: compounds 3, 2 and 1 (each within the scatter of the next, the first and the last beyond it).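

In this assay, among the compounds shown here, the step of a 2.0-fold lower number from compound 2 to compound 3 (0.30 log units; within the scatter) is the first direct reading of this position. Compounds 1 and 2 differ in more than one place and gave no such comparison. It concerns a single aromatic carbon, described as meta to a fused ring and para to a fused ring, where one halogen stands in for another with the rest of the structure unchanged. Compound 2 and compound 3 cannot be told apart in this measurement, so the position accepts bromo in place of chloro with no step that can be separated from repeat measurement, and nothing on hand explains the numbers any further.

This single pair says nothing about groups of another kind at this carbon, so a fluoro, a methyl, a methoxy, a nitrile or an amine there could behave quite differently from the two halogens seen so far. On these data alone, it is also open whether the same exchange would read the same way in another cell line, or with the other chloro of compound 3 replaced by a bromo.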